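The source may report more compounds than this note shows. Statements on the series, on what has been measured and on what is new or still open speak of the compounds shown alone.

Measured so far:
compound 1, `O=[N+]([O-])c1cn2c(n1)OC[C@@H](NCc1ccc(OC(F)(F)F)cc1F)C2`: 72 ug/mL
compound 2, `O=[N+]([O-])c1cn2c(n1)OC[C@@H](NCc1ccc(OC(F)(F)F)c(O)c1)C2`: 56 ug/mL
compound 3, `O=[N+]([O-])c1cn2c(n1)OC[C@@H](NCc1ccc(OC(F)(F)F)cc1O)C2`: 25 ug/mL

Three compounds sharing one core were tested in a physicochemical assay for solubility, at pH 6.8; a lower number here means a less soluble compound, a higher number a more soluble compound. Compound 1 gives 72 ug/mL, compound 2 gives 56 ug/mL, and compound 3 gives 25 ug/mL. Compound 1 and compound 2 lie within the scatter of each other, so nothing separates them. Within the data shown here, compound 2 and compound 3 have the same atoms joined differently; the difference between the two cores is not broken down here, and their two values show only that compound 2 stands higher than compound 3, beyond the scatter.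

Among the measured compounds shown here, the one counted change is fluoro in place of hydroxy on an aromatic carbon, which gives a 2.9-fold higher number from compound 3 to compound 1 (0.46 log units; beyond the scatter).

Compound 4, `O=[N+]([O-])c1cn2c(n1)OC[C@@H](NCc1ccc(OC(F)(F)F)c(F)c1)C2`, has not yet been measured in this assay. It differs from compound 2 by fluoro in place of hydroxy on an aromatic carbon. For the measured compounds named here, this is the same kind of change as the one from compound 3 to compound 1, not the same: there the fluoro enters ortho to a large group and meta to the trifluoromethoxy group, here it enters ortho to the trifluoromethoxy group and meta to a large group.

The expected step from compound 2 to compound 4 is a 2.1-fold higher number from compound 2 to compound 4 (0.33 log units; beyond the scatter), set beside the earlier step because a 2.9-fold higher number from compound 3 to compound 1 (0.46 log units; beyond the scatter) is the only measured case of this kind of change. The shifted surroundings of the change add uncertainty. Compound 4 is expected to give 120 ug/mL, with a range estimated from 50 ug/mL to 260 ug/mL.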

Compound 4, solubility: 43 ug/mL
For compound 4 the middle estimate is 2.8-fold (0.45 log units) above the measured one, and the stated range ends above it.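

In this assay, fluoro in place of hydroxy on an aromatic carbon gives a 1.3-fold lower number from compound 2 to compound 4 (0.11 log units; within the scatter), so nothing separates compound 2 from compound 4, whereas the same kind of change gave a 2.9-fold higher number from compound 3 to compound 1 (0.46 log units; beyond the scatter). The step seen in one setting therefore did not carry over to the other: where the fluoro enters ortho to a trifluoromethoxy group and meta to a large group, the swap leaves no difference that stands clear of the scatter. This does not show that the position of the swap decides its size or that the swap never matters in this setting, for these are only two pairs, each measured once, and nothing shown bears on why their steps differ.

The compounds shown leave open whether a methoxy group, an amine or a carboxylic acid in the place of the hydroxy would stand apart from compound 2 in this assay, and whether such groups would behave differently in the setting of compound 3. They also leave open how the swap of hydroxy for fluoro would read with a trifluoromethyl group in the place of the trifluoromethoxy group, or with a longer chain between the ring and the amine.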